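The compounds below may be only part of what the source reports. "The series", "measured", "known", "first", "only" and "open" are said of these compounds alone.

Compound 1 `C=C[C@@](C)(/C=C/c1ccc(O)c(/C=C/C#N)c1)CCC=C(C)C`: > 43400 nM
Compound 2 `COc1ccc(/C=C/[C@@](C)(/C=C/c2ccc(O)c(C=O)c2)CCC=C(C)C)cc1`: > 43400 nM

Both readings come from a functional assay on NALM-6 cells (Homo sapiens) for cytotoxicity, with a stated time of 72 h; a higher number here means that more compound is needed for the effect, a lower number that less compound is needed. Compound 2 gives > 43400 nM, which is a limit and not a number. Compound 1 likewise gives only a limit, > 43400 nM. Going by the values given here, the series so far therefore sits at the limit of > 43400 nM in this assay, at which 2 of the 2 values shown sit.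

Compound 3 `COc1ccc(/C=C/[C@@](C)(/C=C/c2ccc(O)c(/C=C/C#N)c2)CCC=C(C)C)cc1` has 2-cyanoethenyl in place of formyl on an aromatic carbon, ortho to a hydroxy group: 2-cyanoethenyl in place of formyl on an aromatic carbon.

Among the compounds with values here, no step between measured compounds gives a size to work from. In this assay, no step beyond the scatter is expected in either direction, and another limit reading is likely. The expected change is a step that the limit leaves unreadable from compound 2 to compound 3. For compound 3 the estimated value is 45000 nM, with an expected range of 15000 nM to 100000 nM.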

Compound 3, half-maximal effective concentration: 16500 nM
Compound 3: middle estimate off by 2.7-fold (0.44 log units), on the high side; the range from low to high includes it.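

In this assay, 2-cyanoethenyl in place of formyl gives an at least 2.6-fold lower number from compound 2 to compound 3 (0.42 log units; beyond the scatter). Going by these compounds alone, with 2-cyanoethenyl held fixed, 2-(4-methoxyphenyl)ethenyl in place of vinyl gives an at least 2.6-fold lower number from compound 1 to compound 3 (0.42 log units; beyond the scatter), so of these three compounds only the one carrying both groups gives a number and not a limit. The full size of both steps cannot be read, since each starts from a limit: the limit of > 43400 nM in this assay, at which 2 of the 3 values shown sit.

From the compounds shown here alone, whether a carboxylic acid or an amine on this aromatic carbon would lower the number further stays open. So does the effect of a simple methoxy group in place of the hydroxy group.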